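A few compounds are considered here, and "the series" means these few. Any claim that something is new, unique, unknown or untested is made for them only; others in the source may bear on it.

Measured compounds:
compound 1 `CCCS(=O)(=O)Nc1cccc2c1CCC2c1ncc[nH]1` — 1340 nM
compound 2 `Cc1c(OCC2=NCCN2)ccc(Cl)c1NS(C)(=O)=O` — 25 nM
compound 3 `Cn1nccc1-c1cccc2c1CCC2c1ncc[nH]1` — 278 nM

In a functional assay on CHO cells for agonist activity at Alpha-1A adrenergic receptor (Homo sapiens), read by FLIPR and calcium flux (a higher number here means that more compound is needed for the effect, a lower number that less compound is needed), compound 1 gives 1340 nM, the highest of the three numbers; compound 3 sits nearest to it, while compound 2, a compound built on a different scaffold, gives 25 nM and lies furthest away. For the measured compounds named here, the one step within the shared core of compound 1 is a 4.8-fold lower number from compound 1 to compound 3 (0.68 log units; beyond the scatter), a change that takes out the (propylsulfonyl)amino and puts a five-membered aromatic ring in its place on an aromatic carbon.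

Compound 4 `c1cc(-c2ncco2)c2c(c1)C(c1ncc[nH]1)CC2` is not yet measured. It differs from compound 1 as follows: 1,3-oxazol-2-yl in place of (propylsulfonyl)amino on an aromatic carbon. The group that leaves is the same as in the step to compound 3, and what enters is again a small five-membered aromatic ring, here 1,3-oxazol-2-yl rather than 1-methyl-1H-pyrazol-5-yl. That step is the only one that bears on the question, and it moved the number down by a modest but clear amount. A step of similar direction and size is therefore expected for compound 4 in this assay, a 4.5-fold lower number from compound 1 to compound 4 (0.65 log units; beyond the scatter), with no measured case of this kind of ring swap to narrow it further. The estimate for compound 4 is 300 nM, within a range of 100 nM to 900 nM.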

Compound 4, half-maximal effective concentration: 170 nM
For compound 4 the middle estimate is 1.8-fold (0.25 log units) above the measured one; low and high end bracket the measured number.
By their numbers in this assay, from the lowest: compound 2; then compounds 4 and 3 (each within the scatter of the next); then compound 1.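

At this place on the shared core, an aromatic carbon ortho to a fused ring, a second five-membered aromatic ring now stands in for (propylsulfonyl)amino in this assay and gives a 7.9-fold lower number from compound 1 to compound 4 (0.90 log units; beyond the scatter); the lower number therefore no longer rests on 1-methyl-1H-pyrazol-5-yl alone. Exchanging one ring for the other gives a 1.6-fold lower number from compound 3 to compound 4 (0.21 log units; within the scatter), so 1,3-oxazol-2-yl and 1-methyl-1H-pyrazol-5-yl cannot be told apart in this read-out, and the particular arrangement of hetero atoms and the methyl group make no difference that can be read beyond the scatter for this pair. No measured property is available to account for either step.

What the compounds shown leave open is whether an aromatic ring is needed at this carbon at all, a question that a simple amine or a carboxylic acid in the same place would address. Going by these compounds, it also remains open how a phenyl ring, with carbon only, or a six-membered pyridine ring would compare with the two five-membered rings.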